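Compound 2 to compound 3: chloro in place of methyl

This account rests on a few compounds, and the source may have more. Where it says the series, first, only, none or still open, it means among the compounds named here.

In a functional assay on DU-145 cells (Homo sapiens) for cytotoxicity, read by ELISA, with a stated time of 4 days (a lower number here means a stronger inhibitor, a higher number a weaker inhibitor), compound 2 (`Cc1ccc(-c2cc(-c3ccc(Cl)o3)cc(-c3ccc(Cl)s3)n2)cc1`) gives > 50000 nM, which is a limit of the assay and not a number. Its place in the series is the limit of > 50000 nM in this assay, at which 1 of the 2 values shown sits. Among the measured compounds shown here, compound 1 (`Cc1ccsc1-c1cc(-c2ccc(Cl)o2)cc(-c2ccc(Cl)cc2)n1`) gives 21900 nM in this assay, the only true number so far. Compound 3 (`Clc1ccc(-c2cc(-c3ccc(Cl)o3)cc(-c3ccc(Cl)s3)n2)cc1`) carries chloro in place of methyl on an aromatic carbon, 4-methylphenyl becoming 4-chlorophenyl: chloro in place of methyl on an aromatic carbon. For the measured compounds named here, no measured pair differs in one place, so the size of this change has no direct precedent. In this assay a small step towards lower numbers is expected, perhaps none beyond the scatter, and the reading may stay at the limit. The estimated change is an at least 1.3-fold lower number from compound 2 to compound 3 (0.11 log units; that floor lies within the scatter). The expected value for compound 3 is 38000 nM, with an estimated range of 15000 nM to 70000 nM.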

Compound 3, half-maximal inhibitory concentration: 23000 nM
Estimate against measurement, compound 3: 1.7-fold (0.22 log units) above; measured number inside the range.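

In this assay, among the compounds shown here, replacing methyl with chloro on the phenyl ring, para to a large group, gives an at least 2.1-fold lower number from compound 2 to compound 3 (0.33 log units; beyond the scatter), the first single-place step that is beyond the scatter. From the compounds shown here alone, its true size remains unknown, since the reading for compound 2 is a limit of the assay and not a number: the limit of > 50000 nM in this assay, at which 1 of the 3 values shown sits. With 4-chlorophenyl kept, exchanging 3-methylthiophen-2-yl for 5-chlorothiophen-2-yl gives a 1.1-fold higher number from compound 1 to compound 3 (0.02 log units; within the scatter), so the readings for these two compounds in this assay cannot be told apart.

Going by these compounds, whether the gain from the 4-chlorophenyl group is specific to chloro remains open, as does how an amine or a carboxylic acid para to the same large group would read. Also open, on these data alone, is whether the same methyl-to-chloro change would give a similar step with 3-methylthiophen-2-yl in place of 5-chlorothiophen-2-yl.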